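The compounds below may be only part of what the source reports. "The series", "measured", "known", "first", "only" and "open" are said of these compounds alone.

Of the compounds shown here, three built on one shared core have been tested in a functional assay on PBMC cells (Homo sapiens) for inhibition, read by thymidine incorporation, with a stated time of 72 h; a lower number here means a stronger inhibitor, a higher number a weaker inhibitor. Compound 1 has the structure `CCCCSC(=S)C1=C(Nc2ccc(Cl)cc2)CC(C)(C)CC1=O`. In this assay compound 1 gives > 50 ug/mL, which is a limit of the assay rather than a number. Compound 2, `CCCCCCCCCCCSC(=S)C1=C(Nc2ccc(Cl)cc2)CC(C)(C)CC1=O`, differs from compound 1 by a longer chain: heptyl in place of hydrogen on a saturated chain carbon, four bonds along the chain from a sulfur. In this assay compound 2 gives > 50 ug/mL, again a limit. Compound 3, `CCCCSC(=S)C1=C(Nc2ccc(Br)cc2)CC(C)(C)CC1=O`, differs from compound 1 on the aromatic ring: bromo in place of chloro on an aromatic carbon, and this is the only difference between the two cores. In this assay compound 3 gives > 50 ug/mL, also a limit. Because all values sit at the limit of > 50 ug/mL in this assay, at which 3 of the 3 values shown sit, the step that the two limits leave unreadable from compound 1 to compound 2 and the step that the two limits leave unreadable from compound 1 to compound 3 cannot be given a size; all that can be said is that none of the three compounds shows measurable inhibition within the range of the assay.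

Compound 4, `CCCCCCCCCCCSC(=S)C1=C(Nc2ccc(Br)cc2)CC(C)(C)CC1=O`, has not yet been measured. It carries the same change relative to compound 3 that compound 2 carries relative to compound 1: heptyl in place of hydrogen on a saturated chain carbon, four bonds along the chain from a sulfur, at exactly the same place on the chain. In this assay the expected step is a step that the limit leaves unreadable from compound 3 to compound 4, since the matching measured step that the two limits leave unreadable from compound 1 to compound 2 left compound 2 at the limit of > 50 ug/mL in this assay, at which 3 of the 3 values shown sit. Compound 4 is therefore expected to give 100 ug/mL, most probably as a limit once more.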

Compound 4, half-maximal inhibitory concentration: > 50 ug/mL
Compound 4: no number, only a limit; the forecaster's own chance of this, stated with the estimate: 85%; the middle value does not contradict the limit.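

In this assay compound 4 gives > 50 ug/mL, which is a limit of the assay and not a number. No new step can be read between compound 3 and compound 4 or between compound 2 and compound 4, because all the values share one limit: the limit of > 50 ug/mL in this assay, at which 4 of the 4 values shown sit.

The compounds shown leave open whether heptyl or the change from chloro to bromo alters inhibition at all in this assay.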